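This account rests on a few compounds, and the source may have more. Where it says the series, first, only, none or still open, it means among the compounds named here.

Series notes. Compound 1 `COc1c(OC)c(OC(C)=O)c2cc(C)ccc2c1OC(C)=O` and compound 2 `CCC(=O)Oc1c(OC)c(OC)c(OC(=O)CC)c2cc(C)ccc12` share a core whose difference between the two is not broken down here. In a physicochemical assay for lipophilicity (on this read-out lower numbers stand for lower lipophilicity and higher numbers for higher lipophilicity), compound 1 gives 2.86; in this assay compound 2 gives 3.9, the highest of the three measured numbers. Compound 3 `COc1c(OC)c(OC(C)=O)c2cc(C)c(C)cc2c1OC(C)=O` carries methyl in place of hydrogen on an aromatic carbon relative to compound 1, and in this assay compound 3 gives 3.14; the step is a number 0.28 log units higher from compound 1 to compound 3 (within the scatter). Compound 4 `CCC(=O)Oc1c(OC)c(OC)c(OC(=O)CC)c2cc(C)c(C)cc12` is not yet measured; it carries methyl in place of hydrogen on an aromatic carbon relative to compound 2, the same change at the same place as that seen from compound 1 to compound 3. The step expected for compound 4 in this assay is a number 0.30 log units higher from compound 2 to compound 4 (within the scatter), resting on the earlier step of a number 0.28 log units higher from compound 1 to compound 3 (within the scatter). For compound 4 the expected value in this assay is 4.2, between 3.8 and 4.6.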

Compound 4, partition coefficient: 4.2
Estimate against measurement, compound 4: no gap at the digits printed; low and high end bracket the measured number.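

In this assay methyl in place of hydrogen on an aromatic carbon gives a number 0.30 log units higher from compound 2 to compound 4 (within the scatter) and, on the core of compound 1, a number 0.28 log units higher from compound 1 to compound 3 (within the scatter); the two steps have the same direction and a similar size. This shows that the change carried over between these two cores with no departure from the earlier step, but since each step lies within the scatter, neither pair establishes on its own that the methyl shifts the read-out. Nothing available bears on why the step reads as it does.

The compounds shown leave open whether a longer chain, such as propyl, or an amine at the same place would carry over in the same way. They also leave open whether the methyl step holds on cores beyond these two.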